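Moving the hydroxyl again on a pyridine core

A few compounds are considered here, and "the series" means these few. Any claim that something is new, unique, unknown or untested is made for them only; others in the source may bear on it.

Compound 1 `Oc1cccc(-c2cc(-c3ccccc3)cc(-c3ccsc3)n2)c1` and compound 2 `Oc1ccc(-c2cc(-c3ccccc3)cc(-c3ccsc3)n2)cc1` share one core, and compound 3 `Oc1cccc(-c2cc(-c3ccccc3)nc(-c3ccco3)c2)c1` with the unmeasured compound 4 `Oc1ccc(-c2cc(-c3ccccc3)nc(-c3ccco3)c2)cc1` share another; how the two cores differ is not broken down here. Going by the values given here, in a functional assay on HCT-15 cells (Homo sapiens) for cytotoxicity, read by ELISA, with a stated time of 2 days (on this read-out lower numbers stand for stronger inhibition and higher numbers for weaker inhibition), compound 1 gives 7660 nM, compound 2 gives 1100 nM and compound 3 gives 13900 nM, the highest of the three numbers so far.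

Among the compounds with values here, the one measured step is a 7.0-fold lower number from compound 1 to compound 2 (0.84 log units; beyond the scatter). The change behind it is 4-hydroxyphenyl in place of 3-hydroxyphenyl on an aromatic carbon Compound 4 carries the same kind of change on its own core: 4-hydroxyphenyl in place of 3-hydroxyphenyl on an aromatic carbon The two places are not the same: in compound 1 the site is next to the ring nitrogen and meta to a thiophen-3-yl group, whereas in compound 3 it is opposite the ring nitrogen and meta to a furan-2-yl group. Within the data shown here, the surroundings therefore differ, and only a single earlier instance is known.

Given that, compound 4 is expected to land lower than compound 3 in this assay, because the step of a 7.0-fold lower number from compound 1 to compound 2 (0.84 log units; beyond the scatter) was well beyond the scatter. For compound 4 the estimated value is 3000 nM, with a likely range from 1000 nM to 9000 nM. The estimate for compound 4 corresponds to an expected step of a 4.6-fold lower number from compound 3 to compound 4 (0.67 log units; beyond the scatter), somewhat smaller than the earlier one to allow for the changed surroundings.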

Compound 4, half-maximal inhibitory concentration: 5100 nM
The estimate for compound 4 lay 1.7-fold (0.23 log units) below the measured number; low and high end bracket the measured number.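

In this assay, the move from 3-hydroxyphenyl to 4-hydroxyphenyl on the core of compound 3 gives a 2.7-fold lower number from compound 3 to compound 4 (0.44 log units; beyond the scatter), so the change lowers the number here as it did on the core of compound 1. Set side by side, the two steps cannot be told apart in size: the same change on two cores in this assay, a 7.0-fold lower number (0.84 log units; beyond the scatter) from compound 1 to compound 2 and a 2.7-fold lower number (0.44 log units; beyond the scatter) from compound 3 to compound 4, 2.6-fold (0.41 log units) apart, within the scatter of two such steps This shows that, in these two pairs, the change carried over in direction and that no difference in its size can be claimed, even though the site sits in different surroundings on each core; it does not show that the change would behave the same way on a third core, since two pairs are a thin basis for a rule, and it does not explain why the 4-hydroxyphenyl compounds give the lower numbers.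

The compounds shown leave open whether the same order would hold with a methoxy group, an amine or a carboxylic acid on the phenyl ring in place of the hydroxyl. Going by these compounds alone, they also leave open how much the furan-2-yl and thiophen-3-yl groups contribute on their own, as no pair here differs in that group alone.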